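Methyl on the aryl ring of an inactive thiosemicarbazone pair

The source may report more compounds than this note shows. Statements on the series, on what has been measured and on what is new or still open speak of the compounds shown alone.

In a functional assay on PC-3 cells (Homo sapiens) for inhibition, read by sulforhodamine B assay, with a stated time of 48 h (on this read-out higher numbers stand for weaker inhibition of growth and lower numbers for stronger inhibition of growth), compound 2, `S=C(N/N=C/c1cccs1)Nc1ccccc1`, gives > 100000 nM, which is a limit of the assay and not a number. Compound 1, `S=C(N/N=C/c1cccs1)Nc1ccc(Cl)cc1`, gives > 100000 nM, likewise a limit. The whole record so far is the limit of > 100000 nM in this assay, at which 2 of the 2 values shown sit.

Compound 3, `Cc1ccc(NC(=S)N/N=C/c2cccs2)cc1`, follows from compound 2 by one change: methyl in place of hydrogen on an aromatic carbon, para to a large group.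

Within the data shown here, the only measured step that bears on this change is a step that the two limits leave unreadable from compound 1 to compound 2, a swap of hydrogen for chloro on an aromatic carbon, and it gives no size to carry over. With no readable step to build on, no change beyond the scatter is expected in this assay. The expected step is a number no higher from compound 2 to compound 3 (the limit leaves the size open). Compound 3 is estimated at 100000 nM, with an expected range from 40000 nM to 200000 nM.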

Compound 3, concentration for 50% growth inhibition: 29700 nM
Compound 3: the middle estimate sits 3.4-fold (0.53 log units) above what was measured, outside the stated range (below it).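

In this assay, among these compounds, the aromatic carbon para to a large group now proves responsive to substitution: methyl in place of hydrogen gives an at least 3.3-fold lower number from compound 2 to compound 3 (0.52 log units; beyond the scatter) and is the first readable step. Methyl in place of chloro at that carbon gives an at least 3.3-fold lower number from compound 1 to compound 3 (0.52 log units; beyond the scatter) in the same direction, so methyl stands apart from both hydrogen and chloro here, while the step between hydrogen and chloro cannot be read. Each of the two new steps gives only a minimum size, and the true sizes stay open: the limit of > 100000 nM in this assay, at which 2 of the 3 values shown sit.

The compounds shown leave open whether this effect is particular to methyl or also appears with an ethyl chain, a methoxy group or an amine on the same carbon. They also leave open whether methyl would give a comparable step at any other carbon of the six-membered aromatic ring.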